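The source may hold more compounds than are shown below. What is called first, only, known or untested is meant among the compounds shown, and "the series" means these compounds.

Compound 1 `COc1cc(-c2ccc(C#N)cc2)ccc1Oc1cc(N)nc(Nc2ccc(C#N)cc2)n1` gives 120000 nM in a toxicity assay on MT4 cells (Homo sapiens) for cytotoxicity, read by MTT assay; a higher number here means that more compound is tolerated, a lower number that less compound is tolerated.
Compound 2 `COc1cc(Oc2cc(N)nc(Nc3ccc(C#N)cc3)n2)ccc1-c1ccc(C#N)cc1` gives 12900 nM in this assay.
Compound 3 `Cc1cc(-c2ccc(Cl)cc2)cc(C)c1Oc1cc(N)nc(Nc2ccc(C#N)cc2)n1` gives 21500 nM in this assay.

Among these three numbers compound 3 stands second highest. Its nearest neighbour is compound 2, whose value lies within the usual scatter of repeated measurements, so the two cannot be told apart. Compound 1 is the furthest away, with a clearly higher value beyond the scatter, meaning that more of compound 1 is tolerated by the cells. Compound 4 `Cc1cc(-c2ccc(C#N)c(C#N)c2)cc(C)c1Oc1cc(N)nc(Nc2ccc(C#N)cc2)n1` has not been measured yet. It differs from compound 3 in one place: 3,4-dicyanophenyl in place of 4-chlorophenyl on an aromatic carbon. Among the compounds with values here, no measured pair shows this particular change, so its effect is unknown. The expectation is that the step of a 1.2-fold higher number from compound 3 to compound 4 (0.07 log units; within the scatter) stays within the scatter, with no clear direction. Compound 4 is therefore expected to give about 25000 nM, within a range from 8000 nM to 80000 nM.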

Compound 4, half-maximal cytotoxic concentration: 17600 nM
Beside the measured number, compound 4's estimate is 1.4-fold (0.15 log units) above it; the measured number falls inside the stated range.
By their numbers in this assay, from the lowest: compounds 2, 4 and 3 (each within the scatter of the next); then compound 1.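

At this position, 3,4-dicyanophenyl in place of 4-chlorophenyl gives a 1.2-fold lower number from compound 3 to compound 4 (0.09 log units; within the scatter) in this assay. Within the data shown here, this is the first direct comparison at this place, and it does not separate the two aromatic groups: cells tolerate compound 3 and compound 4 alike. Nothing available explains this result.

Going by these compounds, whether a non-aromatic group here, such as an amine or a carboxylic acid, would also stay within the scatter remains open. A single pair also cannot show whether this swap would behave the same way on another core.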